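A few compounds are considered here, and "the series" means these few. Any claim that something is new, unique, unknown or untested is made for them only; others in the source may bear on it.

Measured so far:
- compound 1 `CC(C(=O)N1CCN(c2ccccc2)CC1)N1C(=O)CCC1=O`: 0%
- compound 2 `CC(C(=O)N1CCN(c2ccc(Cl)cc2)CC1)N1C(=O)CCC1=O`: 0%
- compound 3 `CCC(C(=O)N1CCN(c2ccc(Cl)cc2)CC1)N1C(=O)CCC1=O`: 25%

In a functional assay on the whole organism (strain Swiss) with Mus musculus as the target, in the maximal electroshock model, with a stated time of 2 h, at a dose of 300 mg/kg by the intraperitoneal route (a higher number here means a stronger effect of the compound at the dose given, a lower number a weaker effect), compound 2 gives 0% and compound 1 gives 0%. The change between them is hydrogen in place of chloro on an aromatic carbon, and the step is no change at the digits printed from compound 2 to compound 1 (within the scatter). Compound 3 stands highest of the three measured; the difference between its core and that of compound 2 is methyl in place of hydrogen on a saturated chain carbon, two bonds along the chain from an amide-type nitrogen in a ring and a carbonyl carbon, and the step is a number 25 percentage points higher from compound 2 to compound 3 (beyond the scatter).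

Compound 4 `CCC(C(=O)N1CCN(c2ccccc2)CC1)N1C(=O)CCC1=O` is not yet measured. It differs from compound 3 by hydrogen in place of chloro on an aromatic carbon, the same change as from compound 2 to compound 1; its place line reads the same word for word. Among the compounds with values here, only one earlier instance of this change exists here, and both of its compounds sit at the bottom of the read-out, so it shows little about a step from a higher starting number. The expectation for compound 4 is a small loss, step a number 10 percentage points lower from compound 3 to compound 4 (within the scatter), which rests on the flat step no change at the digits printed from compound 2 to compound 1 (within the scatter) read with that caveat. Compound 4 is estimated at 15%, with a range from 0% to 35%.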

Compound 4, a percentage reported as activity, at one dose (the size of the read-out at that dose, not a potency): 25%
Compound 4: the middle estimate sits 10 percentage points below what was measured; the range from low to high includes it.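

Working notes on the series: in this assay, hydrogen in place of chloro gives no change at the digits printed from compound 3 to compound 4 (within the scatter), and this matches the earlier instance of the change on the core without the added methyl: the same change on two cores in this assay, no change at the digits printed (within the scatter) from compound 2 to compound 1 and no change at the digits printed (within the scatter) from compound 3 to compound 4, 0 percentage points apart, within the scatter of two such steps. The methyl on the saturated chain carbon also carries across, with a number 25 percentage points higher from compound 1 to compound 4 (beyond the scatter) on the phenyl compounds matching the step on the 4-chlorophenyl compounds: the same change on two cores in this assay, a number 25 percentage points higher (beyond the scatter) from compound 2 to compound 3 and a number 25 percentage points higher (beyond the scatter) from compound 1 to compound 4, 0 percentage points apart, within the scatter of two such steps. This shows that both changes read the same on the two cores shown, but it rests on only two pairs at a single dose, compound 1 and compound 2 both sit at the bottom of the read-out, and nothing here establishes potency or extends to other cores.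

From the compounds shown here alone, it remains open whether a longer chain on that same saturated carbon would move the read-out further. Also open, going by these compounds, is how methoxy, fluoro or trifluoromethyl would read in the place of chloro, on either core.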